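The compounds below may be only part of what the source reports. "The series", "measured", "known", "first", "only" and "open" are said of these compounds alone.

Within the data shown here, compound 3 `NCCCC[C@H](NC(=O)CN(c1nc(Cl)nc2[nH]cnc12)C1CC1)C(=O)OCc1ccccc1` gives 41.2% in a functional assay on the whole organism (Tail, strain ICR) with Mus musculus as the target, in the tail flick test, with a stated time of 60 min, at a dose of 25 umol/kg by the oral route (on this read-out lower numbers stand for a weaker effect and higher numbers for a stronger effect at the one dose given), the highest of the three numbers measured so far. Compound 1 `C[C@@H](O)[C@H](NC(=O)CN(c1nc(Cl)nc2[nH]cnc12)C1CC1)C(=O)OCc1ccccc1` gives 29.7%, and compound 2 `O=C(CN(c1nc(Cl)nc2[nH]cnc12)C1CC1)N[C@@H](CC(=O)OCc1ccccc1)C(=O)OCc1ccccc1` gives 22.4%. The steps of a number 11.5 percentage points higher from compound 1 to compound 3 (beyond the scatter) and a number 18.8 percentage points higher from compound 2 to compound 3 (beyond the scatter) both show that the 4-aminobutyl side chain goes with the higher number, whereas a number 7.3 percentage points lower from compound 1 to compound 2 (within the scatter) shows no clear difference between the other two. Compound 4 `CC(C)C[C@H](NC(=O)CN(c1nc(Cl)nc2[nH]cnc12)C1CC1)C(=O)OCc1ccccc1` differs from compound 3 by isopropyl in place of 3-aminopropyl on a saturated chain carbon, two bonds along the chain from an amide-type nitrogen and a carbonyl carbon, so the amine end of the chain is lost. Because a number 18.8 percentage points higher from compound 2 to compound 3 (beyond the scatter) and a number 11.5 percentage points higher from compound 1 to compound 3 (beyond the scatter) tie the stronger effect to that amine, compound 4 is expected to fall back toward the level of compounds 1 and 2, with an expected step of a number 13.2 percentage points lower from compound 3 to compound 4 (beyond the scatter). Compound 4 is therefore estimated at 28%, most likely between 15% and 42%.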

Compound 4, a percentage reported as activity, at one dose (the size of the read-out at that dose, not a potency): 27.3%
Compound 4: the middle estimate sits 0.7 percentage points above what was measured, and the stated range covers the measured number.
By their numbers in this assay, from the lowest: compounds 2, 4 and 1 (each within the scatter of the next); then compound 3.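

In this assay, the change to isopropyl gives a number 13.9 percentage points lower from compound 3 to compound 4 (beyond the scatter) and so removes the lead of compound 3 when the chain keeps its carbons but loses its amine end. The isobutyl side chain also sits level with the other two side chains, with a number 4.9 percentage points higher from compound 2 to compound 4 (within the scatter) and a number 2.4 percentage points lower from compound 1 to compound 4 (within the scatter), so among these four compounds only 4-aminobutyl stands apart. Nothing measured here explains this difference. Still open, on these data alone, is whether a 2-aminoethyl side chain would keep the higher number, and how a free carboxylic acid at the chain end would compare.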